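Aryl exchange on the shared core: compound 3

This account rests on a few compounds, and the source may have more. Where it says the series, first, only, none or still open, it means among the compounds named here.

Compound 1 `Brc1cn2ccnc2c(-c2ccc3ncn(C4CCCCC4)c3c2)n1` gives 26.3% in a functional assay on MOLT-4 cells (Homo sapiens) for inhibition, read by sulforhodamine B assay, with a stated time of 48 h, tested at 10 uM; on this read-out lower numbers stand for less inhibition and higher numbers for more inhibition at the one concentration tested (going by the name of the read-out).
Compound 2 `Fc1ccc(-c2cn3ccnc3c(-c3ccc4ncn(C5CCCCC5)c4c3)n2)cc1` gives 25.2% in this assay.

Compound 2 and compound 1 lie within the scatter of each other: a number 1.1 percentage points lower from compound 1 to compound 2 (within the scatter). Exchanging bromo for 4-fluorophenyl on the aromatic carbon therefore left the read-out essentially unchanged, and compound 2 carries no separate standing of its own on these two numbers.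

Compound 3 `c1cn2cc(-c3ccsc3)nc(-c3ccc4ncn(C5CCCCC5)c4c3)c2n1` differs from compound 2 by thiophen-3-yl in place of 4-fluorophenyl on an aromatic carbon. Among the compounds with values here, the only measured step, a number 1.1 percentage points lower from compound 1 to compound 2 (within the scatter), concerns the same aromatic carbon and lay within the scatter, so it offers no sign that the group at this position moves the read-out. Within the data shown here, no measured compound carries a thiophen-3-yl, so the expectation rests on that one step alone. Compound 3 is therefore expected to give a number within the scatter of compound 2, that is a number 0.2 percentage points lower from compound 2 to compound 3 (within the scatter), estimated at 25% with a range from 10% to 40%.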

Compound 3, a percentage reported as inhibition, at one concentration (the size of the read-out at that concentration, not a potency): 30%
Beside the measured number, compound 3's estimate is 5 percentage points below it; low and high end bracket the measured number.
By their numbers in this assay, from the lowest: compounds 2, 1 and 3 (each within the scatter of the next).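

Thiophen-3-yl on the same aromatic carbon gives a number 4.8 percentage points higher from compound 2 to compound 3 (within the scatter) in this assay, and against the bromo the step is a number 3.7 percentage points higher from compound 1 to compound 3 (within the scatter). Within the data shown here, this position has now held bromo, a six-membered aromatic ring of carbon only and a five-membered aromatic ring with a sulfur atom and one hydrogen-bond acceptor, and no step among the three compounds lies beyond the scatter, so neither the change of ring size nor the added acceptor shows in the read-out. Nothing at hand bears on why these numbers stay together.

From the compounds shown here alone, whether an amine, a carboxylic acid or a longer chain on this aromatic carbon would give a step beyond the scatter stays open. Also open, going by these compounds, is what a replacement of the cyclohexyl group, common to all three compounds, would do to the read-out.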